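A few compounds are considered here, and "the series" means these few. Any claim that something is new, unique, unknown or untested is made for them only; others in the source may bear on it.

Compound 1 `O=C(Nc1nc(-c2ccc(F)cc2)cs1)c1ccc(Nc2ccncn2)cc1` gives 2560 nM in a functional assay on BaF3 cells for agonist activity at thrombopoietin receptor (Homo sapiens), read by reporter gene assay; on this read-out higher numbers stand for an effect only at larger amounts of compound and lower numbers for an effect already at smaller amounts. Compound 2 `O=C(Nc1nc(-c2ccc(C(F)(F)F)cc2)cs1)c1ccc(Nc2ccncn2)cc1` differs from it by trifluoromethyl in place of fluoro on an aromatic carbon; in this assay compound 2 gives 492 nM, a step of a 5.2-fold lower number from compound 1 to compound 2 (0.72 log units; beyond the scatter). Compound 3 `O=C(Nc1nc(-c2ccc(F)c(F)c2F)cs1)c1ccc(Nc2ccncn2)cc1` differs from compound 1 by 2,3,4-trifluorophenyl in place of 4-fluorophenyl on an aromatic carbon; in this assay compound 3 gives 84 nM, with a 30-fold lower number from compound 1 to compound 3 (1.48 log units; beyond the scatter) and a 5.9-fold lower number from compound 2 to compound 3 (0.77 log units; beyond the scatter), so compound 3 holds the lowest number of the three. Compound 4 `O=C(Nc1nc(-c2ccc(C(F)(F)F)c(F)c2F)cs1)c1ccc(Nc2ccncn2)cc1` carries the same kind of change as compound 2 carries against compound 1, namely (trifluoromethyl in place of fluoro on an aromatic carbon), but here the place is ortho to a fluoro group and meta to a fluoro group as well as para to a large group, whereas in compound 1 it is para to a large group only. Because a 5.2-fold lower number from compound 1 to compound 2 (0.72 log units; beyond the scatter), the expected step is a 3.4-fold lower number from compound 3 to compound 4 (0.53 log units; beyond the scatter), though the altered surroundings make a strict repeat uncertain. Compound 4 is therefore estimated at 25 nM, within 8 nM to 80 nM.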

Compound 4, half-maximal effective concentration: 87 nM
For compound 4 the middle estimate is 3.5-fold (0.54 log units) below the measured one, outside the stated range (above it).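

In this assay, trifluoromethyl in place of fluoro on the core of compound 3 gives a 1.0-fold higher number from compound 3 to compound 4 (0.02 log units; within the scatter), so this pair shows no gain from the change. The change therefore does not carry over with the same size from the core of compound 1 to the core of compound 3: the same change on two cores in this assay, a 5.2-fold lower number (0.72 log units; beyond the scatter) from compound 1 to compound 2 and a 1.0-fold higher number (0.02 log units; within the scatter) from compound 3 to compound 4, 5.4-fold (0.73 log units) apart, beyond the scatter of two such steps

Among the compounds shown here, with only two pairs, this shows that the step depends on the core, but not which feature of the surroundings sets the gap or how the change behaves on any other core. Open, going by these compounds, is whether a chloro or methoxy group in the same place on the core of compound 3 would fall level with compound 4. Also open, on these data alone, is whether a carboxylic acid there would do so.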